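Replacing the aryl amide with a pentyl chain

A few compounds are considered here, and "the series" means these few. Any claim that something is new, unique, unknown or untested is made for them only; others in the source may bear on it.

Compound 1 `COc1ccc(NC(=O)COc2cc(C)nc3ccc(OC)cc23)cc1` and compound 2 `COc1ccc2nc(C)cc(OCC(=O)Nc3ccc(C)cc3)c2c1` share one core and differ by methyl in place of methoxy on an aromatic carbon. In an ADME assay on HepG2 cells (Homo sapiens) for cytotoxicity, read by trypan blue exclusion, with a stated time of 48 h, in the presence of a further agent that is not named here (on this read-out lower numbers stand for higher toxicity in this test and higher numbers for lower toxicity in this test), compound 1 gives > 142000 nM, which is a limit of the assay and not a number. In this assay compound 2 gives > 149000 nM, again a limit of the assay rather than a number. The step that the two limits leave unreadable from compound 1 to compound 2 therefore cannot be read, since the limit of > 142000 nM in this assay, at which 1 of the 2 values shown sits, and the limit of > 149000 nM in this assay, at which 1 of the 2 values shown sits, each hold one of the two values shown. Compound 3 `CCCCCNC(=O)COc1cc(C)nc2ccc(OC)cc12` differs from compound 2 by pentyl in place of 4-methylphenyl on an amide-type nitrogen. Going by the values given here, no measured step bears directly on this change, and the one comparison at hand, from compound 1 to compound 2, is unreadable. Compound 3 is therefore expected to show no step beyond the scatter, a step that the limit leaves unreadable from compound 2 to compound 3, with a limit the likeliest outcome. Compound 3 is estimated at 150000 nM, between 50000 nM and 450000 nM.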

Compound 3, half-maximal cytotoxic concentration: > 158000 nM
Compound 3 gave a limit, no number (the forecaster's own chance of this, stated with the estimate: 75%); at least 1.0-fold (0.02 log units) between middle value and limit.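

In this assay compound 3 gives > 158000 nM, a limit of the assay and not a number, so neither the step from compound 1 to compound 3 nor the step from compound 2 to compound 3 can be read. The compounds shown leave open whether 4-methoxyphenyl, 4-methylphenyl and pentyl on the amide-type nitrogen differ at all in half-maximal cytotoxic concentration.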